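A Nitrile-Bearing Aryl Group on the Shared Core

The source may report more compounds than this note shows. Statements on the series, on what has been measured and on what is new or still open speak of the compounds shown alone.

Values measured in a functional assay on C8166 cells (Homo sapiens) for cytotoxicity, read by MTT assay (a higher number here means that more compound is tolerated, a lower number that less compound is tolerated), so far
Compound 1 `Cc1cc(S(N)(=O)=O)ccc1NC(=O)COc1ccc(Cl)cc1NC(=O)c1cccc(F)c1` gives 243000 nM
Compound 2 `Cc1cc(S(N)(=O)=O)ccc1NC(=O)COc1ccc(Cl)cc1NC(=O)c1ccc(Cl)c(Cl)c1` gives 158000 nM

Among the compounds with values here, with only two compounds measured, compound 2 stands within the usual scatter of compound 1, so the pair cannot be ranked. The next compound, compound 3 `Cc1cc(S(N)(=O)=O)ccc1NC(=O)COc1ccc(Cl)cc1NC(=O)c1cc(Cl)cc(C#N)c1`, keeps the shared core and carries 3-chloro-5-cyanophenyl in place of 3,4-dichlorophenyl on a carbonyl carbon. Within the data shown here, one measured step bears on this change, and it is at the same place: a 1.5-fold lower number from compound 1 to compound 2 (0.19 log units; within the scatter). That exchange of one aryl group for another stayed within the scatter. Among the measured compounds shown here, no measured compound carries a nitrile, so this single step is thin evidence, and the range is kept wide. The expected step is a 1.1-fold higher number from compound 2 to compound 3 (0.03 log units; within the scatter), which means no change beyond the scatter is anticipated in this assay. For compound 3 the estimated value is 170000 nM, with an expected range from 80000 nM to 330000 nM.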

Compound 3, half-maximal cytotoxic concentration: 131000 nM
Compound 3: the middle estimate sits 1.3-fold (0.11 log units) above what was measured, within the range that was stated.
By their numbers in this assay, from the lowest: compounds 3, 2 and 1 (each within the scatter of the next).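

In this assay, within the data shown here, the first nitrile-bearing group at this position, 3-chloro-5-cyanophenyl on the carbonyl carbon, gives a 1.2-fold lower number from compound 2 to compound 3 (0.08 log units; within the scatter) and a 1.9-fold lower number from compound 1 to compound 3 (0.27 log units; within the scatter) and so stands within the scatter of both earlier aryl groups. Across compound 1, compound 2 and compound 3, then, this position takes three differently substituted phenyl groups, one of them carrying a nitrile, without a step beyond the scatter. No measurement at hand offers an explanation for this result.

Going by these compounds, all three compounds keep a substituted phenyl group on this carbonyl carbon, so the effect of an amine, a carboxylic acid or a longer alkyl chain there stays open. On these data alone, whether this assay responds to a change elsewhere on the shared core also remains open.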